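From Compound 3 to Compound 4: One Ring Group Exchanged

The compounds below may be only part of what the source reports. "The series", "measured", "known", "first", "only" and "open" are said of these compounds alone.

In a functional assay on MCF7 cells (Homo sapiens) for antiproliferative activity, read by MTT assay, with a stated time of 72 h (a higher number here means a weaker inhibitor, a lower number a stronger inhibitor), compound 3 `CCOC(=O)C1CCN(CCCOc2cc3ncnc(Nc4ccc(C#N)cc4)c3cc2OC)CC1` gives 34900 nM and compound 1 `COc1cc2c(Nc3ccc(C#N)cc3)ncnc2cc1OCCCN(C)C` gives 45000 nM, so the two stand level within the scatter. In this assay, compound 2 `COc1cc2c(Nc3ccc(C#N)cc3)ncnc2cc1OCCCN1CCCCC1CCO` gives only a limit, > 100000 nM.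

Compound 4 `COc1cc2c(Nc3ccc(C#N)cc3)ncnc2cc1OCCCN1CCN(C)CC1` carries 4-methylpiperazin-1-yl in place of the 4-(ethoxycarbonyl)piperidin-1-yl of compound 3, on a saturated chain carbon, three bonds along the chain from an oxygen on an aromatic ring: 4-methylpiperazin-1-yl in place of 4-(ethoxycarbonyl)piperidin-1-yl on a saturated chain carbon, three bonds along the chain from an oxygen on an aromatic ring.

The closest guide is the exchange of dimethylamino for 4-(ethoxycarbonyl)piperidin-1-yl at that same place, which gave a 1.3-fold lower number from compound 1 to compound 3 (0.11 log units; within the scatter). The larger steps, an at least 2.2-fold higher number from compound 1 to compound 2 (0.34 log units; beyond the scatter) and an at least 2.8-fold lower number from compound 2 to compound 3 (0.45 log units; beyond the scatter), both involve the 2-(2-hydroxyethyl)piperidin-1-yl group, which compound 4 does not carry. No change beyond the scatter is therefore expected in this assay, and the expected step is a 1.1-fold higher number from compound 3 to compound 4 (0.06 log units; within the scatter). Compound 4 is estimated at 40000 nM, with an expected range of 15000 nM to 90000 nM.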

Compound 4, half-maximal inhibitory concentration: 71100 nM
Compound 4: middle estimate off by 1.8-fold (0.25 log units), on the low side, within the range that was stated.
By their numbers in this assay, from the lowest: compounds 3, 1 and 4 (each within the scatter of the next, the first and the last beyond it). At a limit, above all of these: compound 2.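

In this assay, the exchange of 4-(ethoxycarbonyl)piperidin-1-yl for 4-methylpiperazin-1-yl gives a 2.0-fold higher number from compound 3 to compound 4 (0.31 log units; beyond the scatter), so two ring groups without a hydroxyethyl arm can now be told apart at this position, if only modestly. Dimethylamino does not separate from the new group, with a 1.6-fold higher number from compound 1 to compound 4 (0.20 log units; within the scatter), which leaves the open-chain amine within the scatter of both ring groups. The step of an at least 1.4-fold lower number from compound 2 to compound 4 (0.14 log units; that floor lies within the scatter) is only a floor, and its true size cannot be read: the limit of > 100000 nM in this assay, at which 1 of the 4 values shown sits.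

The exchange removes the ethoxycarbonyl group and adds a second ring nitrogen in one move, so the compounds shown cannot say which of the two goes with the step. On these data alone, a plain piperidin-1-yl at this place would separate the two, and the effect of a longer chain also remains open.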